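The compounds below may be only part of what the source reports. "The series", "measured", "known", "first", "only" and "open" are said of these compounds alone.

In an ADME assay on A549 cells (Homo sapiens) for cytotoxicity, read by LDH release, with a stated time of 15 h (on this read-out lower numbers stand for higher toxicity in this test and higher numbers for lower toxicity in this test), compound 1 (`O=C(Nc1ccc(NCC2CCCC2)cc1Cl)c1cc(Cl)ccc1O`) gives 141000 nM, compound 2 (`CCCC(C)(C)Nc1ccc(NC(=O)c2cc(Cl)ccc2O)c(Cl)c1`) gives 23700 nM and compound 3 (`CC(C)Nc1ccc(NC(=O)c2cc(Cl)ccc2O)c(Cl)c1`) gives 82700 nM. Compound 3 cannot be told apart from compound 1, as a 1.7-fold lower number from compound 1 to compound 3 (0.23 log units; within the scatter) stays within the scatter, but it stands clear of compound 2, as a 3.5-fold higher number from compound 2 to compound 3 (0.54 log units; beyond the scatter) goes beyond it. Compound 4 (`CCCNc1ccc(NC(=O)c2cc(Cl)ccc2O)c(Cl)c1`) keeps the shared core and carries propyl in place of isopropyl on a nitrogen on an aromatic ring. Changes at this nitrogen have mattered, with a 5.9-fold lower number from compound 1 to compound 2 (0.77 log units; beyond the scatter) as the largest, yet none of them is this exact swap. A small upward shift at most, inside the scatter, is therefore expected in this assay. The expected step is a 1.2-fold higher number from compound 3 to compound 4 (0.08 log units; within the scatter). Compound 4 is estimated at 100000 nM, with a likely range of 45000 nM to 210000 nM.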

Compound 4, half-maximal cytotoxic concentration: 69700 nM
Beside the measured number, compound 4's estimate is 1.4-fold (0.16 log units) above it; the range from low to high includes it.
By their numbers in this assay, from the lowest: compound 2; then compounds 4, 3 and 1 (each within the scatter of the next, the first and the last beyond it).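

In this assay, swapping the branched isopropyl for the straight propyl, with the same atoms joined differently, gives a 1.2-fold lower number from compound 3 to compound 4 (0.07 log units; within the scatter) and so makes no readable difference at this nitrogen. Against the larger groups, a 2.9-fold higher number from compound 2 to compound 4 (0.47 log units; beyond the scatter) and a 2.0-fold lower number from compound 1 to compound 4 (0.31 log units; beyond the scatter) both lie beyond the scatter and point in opposite directions, so among these compounds a larger group does not shift the number one way. Still open, going by these compounds, is how a longer chain such as hexyl, or a terminal amine on the propyl chain, would read here. Nothing measured here explains these shifts.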